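The compounds below may be only part of what the source reports. "The series", "measured", "known", "first", "only" and "open" are said of these compounds alone.

- Compound 1 `CCOC(=O)C(C)Oc1c(-c2ccc(OC)cc2)oc2c(CC=C(C)C)c(O)cc(O)c2c1=O`: 4600 nM
- Compound 2 `COc1ccc(-c2oc3c(CC=C(C)C)c(OC(C)C(=O)O)cc(O)c3c(=O)c2O)cc1`: 15300 nM

Among the compounds with values here, in a functional assay on A549 cells (Homo sapiens) for cytotoxicity, read by MTT assay (a higher number here means a weaker inhibitor, a lower number a stronger inhibitor), compound 1 gives 4600 nM, the lowest of the two numbers so far. Compound 2 reads 15300 nM, higher by more than the scatter. Compound 3 `CCOC(=O)COc1c(-c2ccc(OC)cc2)oc2c(CC=C(C)C)c(O)cc(O)c2c1=O` departs from compound 1 at one place: hydrogen in place of methyl on a saturated chain carbon bound to a carbonyl carbon and an oxygen on an aromatic ring. Within the data shown here, no measured pair shows this change, so no step beyond the scatter is expected in this assay. The expected step is a 1.1-fold higher number from compound 1 to compound 3 (0.04 log units; within the scatter). Compound 3 is estimated at 5000 nM, with a range of 2000 nM to 12500 nM.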

Compound 3, half-maximal inhibitory concentration: 65200 nM
Estimate against measurement, compound 3: 13-fold (1.12 log units) below; the measured number lies above the stated range.
By their numbers in this assay, from the lowest: compound 1; then compound 2; then compound 3.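

In this assay, hydrogen in place of methyl on a saturated chain carbon bound to a carbonyl carbon and an oxygen on an aromatic ring gives a 14-fold higher number from compound 1 to compound 3 (1.15 log units; beyond the scatter) as 1-(ethoxycarbonyl)ethoxy becomes (ethoxycarbonyl)methoxy. Within the data shown here, this is the first single-place comparison, and it shows that this one methyl carries a large difference at this position. Nothing available explains the step. From the compounds shown here alone, whether a longer chain, such as ethyl, on that carbon would give a lower number remains open. So does whether an amide in place of the ethyl ester would keep the difference.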